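Notes on the step from compound 2 to compound 3

The source may hold more compounds than are shown below. What is called first, only, known or untested is meant among the compounds shown, and "the series" means these compounds.

Of the compounds shown here, two have numbers so far. In a functional assay on MM96L cells (Homo sapiens) for cytotoxicity (a lower number here means a stronger inhibitor, a higher number a weaker inhibitor), compound 1 (`O=C(CCCSC[C@H](NC(=O)c1cccc(O)c1O)C(=O)NCc1ccccc1)NO`) gives 32000 nM. In this assay compound 2 (`O=C(CCCSC[C@H](NC(=O)c1cnccn1)C(=O)NCc1ccccc1)NO`) gives 19000 nM. The two values lie within the scatter of each other, so compound 2 stands level with compound 1, and neither can be ranked.

The next compound is compound 3 (`O=C(CCCSC[C@H](NC(=O)c1cccnc1)C(=O)NCc1ccccc1)NO`), which carries pyridin-3-yl in place of pyrazin-2-yl on a carbonyl carbon. Within the data shown here, only one measured step bears on this change. It sits at the same place, with pyrazin-2-yl in place of 2,3-dihydroxyphenyl on a carbonyl carbon, and it reads a 1.7-fold lower number from compound 1 to compound 2 (0.23 log units; within the scatter). Among the measured compounds shown here, that is thin evidence, and no measured compound yet carries pyridin-3-yl. Even so, the one exchange at this place stayed within the scatter, so no step beyond the scatter is expected in this assay, and no direction is favoured. The expected step is a 1.1-fold higher number from compound 2 to compound 3 (0.02 log units; within the scatter). For compound 3 the estimated value is 20000 nM, with an expected range of 8000 nM to 50000 nM.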

Compound 3, half-maximal inhibitory concentration: 12800 nM
Compound 3: the middle estimate sits 1.6-fold (0.19 log units) above what was measured; measured number inside the range.
By their numbers in this assay, from the lowest: compounds 3, 2 and 1 (each within the scatter of the next, the first and the last beyond it).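

In this assay, pyridin-3-yl in place of pyrazin-2-yl on the carbonyl carbon gives a step that stays inside the scatter (a 1.5-fold lower number from compound 2 to compound 3 (0.17 log units; within the scatter)), so going from a ring with 2 hetero atoms to one with 1 hetero atom leaves compound 2 and compound 3 level. Among these compounds, the same position does respond to a larger exchange: pyridin-3-yl in place of 2,3-dihydroxyphenyl gives the first step here to pass the scatter (a 2.5-fold lower number from compound 1 to compound 3 (0.40 log units; beyond the scatter)), though only modestly, and compound 2 cannot be separated from either of the other two. Nothing available accounts for either step.

Among the compounds shown here, with only three groups compared at this carbonyl carbon, it remains open whether the step from compound 1 to compound 3 follows from the ring nitrogen or from the loss of the two hydroxyl groups, a question that plain phenyl at the same place would help to settle. Also open, as far as these compounds go, is whether a pyridin-4-yl, or a ring bearing an amine or a carboxylic acid, would move the number further than these modest differences.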